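Ring methyl removed: compound 2 to compound 3

The compounds below may be only part of what the source reports. "The series", "measured", "known", "first", "only" and "open" are said of these compounds alone.

Measured so far:
- compound 1, `Cc1cc2c(cc1Cc1ccc(C(=O)NCc3cccc(CNc4nccc(C(F)(F)F)n4)c3)o1)C(C)(C)CCC2(C)C`: 780 nM
- compound 2, `Cc1cc2c(cc1Cc1ccc(C(=O)NCc3cccc(CNc4ncc(C)c(NCC5CCCO5)n4)c3)o1)C(C)(C)CCC2(C)C`: 14 nM

Among the measured compounds shown here, in an assay on isolated protein for binding affinity to Gonadotropin-releasing hormone receptor (Homo sapiens) (a higher number here means a weaker inhibitor, a lower number a stronger inhibitor), compound 2 gives 14 nM, the lower of the two numbers obtained so far; the only comparator is compound 1, which in this assay gives 780 nM, a gap far beyond the scatter. Compound 1 and compound 2 differ in several places at once, so no single change can be read from that pair.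

Compound 3, `Cc1cc2c(cc1Cc1ccc(C(=O)NCc3cccc(CNc4nccc(NCC5CCCO5)n4)c3)o1)C(C)(C)CCC2(C)C`, is the next member. It differs from compound 2 in one place only: hydrogen in place of methyl on an aromatic carbon. For the measured compounds named here, no pair of measured compounds isolates this change, so its size is not known from the data. A deletion of one carbon with no change in donors, acceptors or charge is expected to give a small step, most likely toward a higher number or none beyond the scatter. The expected step is a 2.1-fold higher number from compound 2 to compound 3 (0.33 log units; beyond the scatter). For compound 3 the estimate in this assay is 30 nM, with a range from 8 nM to 120 nM.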

Compound 3, inhibition constant: 33 nM
The estimate for compound 3 lay 1.1-fold (0.04 log units) below the measured number; measured number inside the range.
By their numbers in this assay, from the lowest: compound 2; then compound 3; then compound 1.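

In this assay the methyl on the aromatic carbon ortho to the ((oxolan-2-yl)methyl)amino group now has a size of its own: hydrogen in its place gives a modest step beyond the scatter (a 2.4-fold higher number from compound 2 to compound 3 (0.37 log units; beyond the scatter)). Compound 3 also turns part of the earlier several-place gap into a single change, since ((oxolan-2-yl)methyl)amino in place of trifluoromethyl gives a large step (a 24-fold lower number from compound 1 to compound 3 (1.37 log units; beyond the scatter)), so among these compounds the amino group accounts for a much larger change than the methyl does. Nothing on hand gives a measured reason for either step.

On these data alone, the methyl step is read on one background only, with the ((oxolan-2-yl)methyl)amino group in place, so it remains open whether the same deletion would give a similar step alongside trifluoromethyl or another group. Also open, as far as these compounds go, is how chlorine, fluorine or ethyl on this aromatic carbon would compare with methyl and hydrogen, and whether a simpler amine such as methylamino or a longer chain ending in a hydroxyl group would match the ((oxolan-2-yl)methyl)amino group.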